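Swapping a Chlorophenyl for a Pyridyl: Cytotoxicity Outlook

The compounds below may be only part of what the source reports. "The series", "measured", "known", "first", "only" and "open" are said of these compounds alone.

Measured compounds:
compound 1: `Clc1cccc(Cn2ccc3nc(-c4ccccc4)nc-3c2)c1` — > 100000 nM
compound 2: `CC(c1ccccc1)n1ccc2nc(-c3ccccc3)nc-2c1` — > 100000 nM

Of the compounds shown here, two have so far been tested in an ADME assay on MDBK cells (Bos taurus) for cytotoxicity; a higher number here means that more compound is tolerated, a lower number that less compound is tolerated. Compound 1 gives > 100000 nM, which is a limit of the assay and not a number. Compound 2 likewise gives > 100000 nM, again a limit rather than a number. Among the compounds with values here, compound 1 thus stands at the edge of what the assay reports, and the one further value known sits at the same edge, as the limit of > 100000 nM in this assay, at which 2 of the 2 values shown sit, shows. Within the data shown here, no pair of measured compounds differs in a single place, so no step size can be read from the data.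

The next compound, compound 3, `c1ccc(-c2nc3ccn(Cc4cccnc4)cc-3n2)cc1`, differs from compound 1 in one place: pyridin-3-yl in place of 3-chlorophenyl on a saturated chain carbon bound to an aromatic nitrogen. With both measured compounds resting at the limit, there is nothing to suggest that this change will bring cytotoxicity into the measurable range. In this assay the expected step is a number no higher from compound 1 to compound 3 (the limit leaves the size open), that is, none beyond the scatter. Compound 3 is therefore estimated at 100000 nM, with a range from 30000 nM to 300000 nM, and most likely will again be reported only as a limit.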

Compound 3, half-maximal cytotoxic concentration: > 100000 nM
Compound 3 ended at the assay's limit; the forecaster's own chance of this, stated with the estimate: 80%; the middle value sits exactly at the limit.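

In this assay compound 3 gives > 100000 nM, which is a limit of the assay and not a number. Compound 1 also rests at a limit, so no step can be read between compound 1 and compound 3: the limit of > 100000 nM in this assay, at which 3 of the 3 values shown sit.

The compounds shown leave open whether pyridin-3-yl and 3-chlorophenyl differ at all in cytotoxicity, and what concentration any of these compounds would actually need to reach it.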